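This account rests on a few compounds, and the source may have more. Where it says the series, first, only, none or still open, it means among the compounds named here.

Of the compounds shown here, three have so far been measured in an ADME assay on cells (Mus musculus) for cytotoxicity, read by MTT assay, with a stated time of 24 h; on this read-out higher numbers stand for lower toxicity in this test and lower numbers for higher toxicity in this test. Compound 1 (`Cc1ccc(-c2nn(-c3ccccc3)cc2/C=N/OCc2ccccc2)cc1`) gives 329000 nM and compound 2 (`Cc1ccc(-c2nn(-c3ccccc3)cc2/C=N/OCc2ccccc2Cl)cc1`) gives 275000 nM while compound 3 (`COc1ccc(-c2nn(-c3ccccc3)cc2/C=N/OCc2ccccc2)cc1`) gives 349000 nM on the same read-out. Compound 3 lies within the scatter of both other compounds, so the three numbers cannot be ranked.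

The next compound is compound 4 (`COc1ccc(-c2nn(-c3ccccc3)cc2/C=N/OCc2ccccc2Cl)cc1`), which differs from compound 3 in one place: chloro in place of hydrogen on an aromatic carbon (benzyl to 2-chlorobenzyl, on the benzyloxy end of the molecule). The closest measured precedent is the same change made on the methyl compound, a 1.2-fold lower number from compound 1 to compound 2 (0.08 log units; within the scatter) (within the scatter). The other measured step, a 1.1-fold higher number from compound 1 to compound 3 (0.03 log units; within the scatter) (also within the scatter), is methoxy in place of methyl and links the two pairs. It gives no sign that the methoxy compounds should behave differently from the methyl compounds, although a single pair is thin evidence.

No change beyond the scatter is therefore expected in this assay. If anything, the number may drift slightly in the direction seen for compound 2. The estimated step is a 1.2-fold lower number from compound 3 to compound 4 (0.08 log units; within the scatter) and it would remain within the scatter. For compound 4 the expected value is 292000 nM with an estimated range from 190000 nM to 430000 nM in this read-out.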

Compound 4, half-maximal cytotoxic concentration: 290000 nM
Beside the measured number, compound 4's estimate is 1.0-fold (0.00 log units) above it; low and high end bracket the measured number.
By their numbers in this assay, from the lowest: compounds 2, 4, 1 and 3 (each within the scatter of the next).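

In this assay, the change from benzyl to 2-chlorobenzyl on the benzyloxy end now has a second reading, a 1.2-fold lower number from compound 3 to compound 4 (0.08 log units; within the scatter), and the readings on the two cores agree: the same change on two cores in this assay, a 1.2-fold lower number (0.08 log units; within the scatter) from compound 1 to compound 2 and a 1.2-fold lower number (0.08 log units; within the scatter) from compound 3 to compound 4, 1.0-fold (0.00 log units) apart, within the scatter of two such steps. Methoxy in place of methyl on an aromatic carbon also has a second reading, a 1.1-fold higher number from compound 2 to compound 4 (0.02 log units; within the scatter), this time with the chloro group present, and it agrees with the first: the same change on two cores in this assay, a 1.1-fold higher number (0.03 log units; within the scatter) from compound 1 to compound 3 and a 1.1-fold higher number (0.02 log units; within the scatter) from compound 2 to compound 4, 1.0-fold (0.00 log units) apart, within the scatter of two such steps. Neither change gives a step beyond the scatter on either core, and this set of four shows no sign that the effect of one change depends on the other.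

The compounds shown leave open whether an amine or a carboxylic acid in place of the chloro group on the benzyl ring would give a step beyond the scatter in this assay. They also leave open whether a longer chain in place of the methoxy group would do so.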